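The compounds below may be only part of what the source reports. "The series", "measured", "known", "first", "only" and "open" are said of these compounds alone.

Of the compounds shown here, three have so far been measured in a functional assay on DU-145 cells (Homo sapiens) for cytotoxicity, read by CCK-8 assay and cell counting, with a stated time of 2 days; on this read-out lower numbers stand for stronger inhibition and higher numbers for weaker inhibition. Compound 3 `Oc1cccc(-c2cc(-c3ccccc3)nc(-c3cccc(Cl)c3)c2)c1` gives 2750 nM, the lowest of the three numbers. Compound 1 `Oc1ccc(-c2cc(-c3ccsc3)nc(-c3cccc(Cl)c3)c2)cc1` gives 6220 nM, and compound 2 `Oc1cccc(-c2cc(-c3ccccc3)nc(-c3ccc(Cl)cc3)c2)c1` gives 11200 nM. For the measured compounds named here, the only one-place step among them is a 4.1-fold lower number from compound 2 to compound 3 (0.61 log units; beyond the scatter), which concerns the position of the chlorine and does not bear on the change at hand. Compound 4 `Oc1ccc(-c2cc(-c3ccccc3)nc(-c3cccc(Cl)c3)c2)cc1` has not been measured; it differs from compound 3 by 4-hydroxyphenyl in place of 3-hydroxyphenyl on an aromatic carbon. Compound 1 also carries a 4-hydroxyphenyl group, yet it differs from compound 3 in a second place too, so its number only hints at a mild rise. Going by the values given here, with no directly bearing step, a step of a 1.6-fold higher number from compound 3 to compound 4 (0.21 log units; within the scatter) is expected, near the scatter. Compound 4 is therefore estimated at 4500 nM, within 1800 nM to 11000 nM.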

Compound 4, half-maximal inhibitory concentration: 5360 nM
The estimate for compound 4 lay 1.2-fold (0.08 log units) below the measured number; the range from low to high includes it.
By their numbers in this assay, from the lowest: compounds 3, 4, 1 and 2 (each within the scatter of the next, the first and the last beyond it).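

With 4-hydroxyphenyl in place of 3-hydroxyphenyl opposite the ring nitrogen, the result is a 1.9-fold higher number from compound 3 to compound 4 (0.29 log units; within the scatter), so the two placements of the hydroxyl cannot be told apart here. Phenyl in place of thiophen-3-yl gives a 1.2-fold lower number from compound 1 to compound 4 (0.06 log units; within the scatter), so these two groups cannot be told apart either, at least alongside 4-hydroxyphenyl. No measurement on hand explains either result. Still open, going by these compounds, is whether an amine, a carboxylic acid or a methoxy group in place of the hydroxyl would give a step beyond the scatter.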